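Thiophene swap on a series at its assay limit

The compounds below may be only part of what the source reports. "The series", "measured", "known", "first", "only" and "open" are said of these compounds alone.

- Compound 1 `O=C(Nc1ccc(F)cc1)c1cc(=O)[nH]c2cc(Br)ccc12` gives > 20000 nM as a limit
- Compound 2 `O=C(Nc1cccc(C(F)(F)F)c1)c1cc(=O)[nH]c2cc(Br)ccc12` gives > 20000 nM as a limit
- Compound 3 `CC(C)(C)c1ccc(-c2ccc3c(C(=O)Nc4cccc(F)c4)cc(=O)[nH]c3c2)cc1` gives > 20000 nM as a limit

In a functional assay on KYSE-410 cells (Homo sapiens) for antiproliferative activity, read by MTT assay, with a stated time of 72 h (on this read-out higher numbers stand for weaker inhibition and lower numbers for stronger inhibition), compound 3 gives > 20000 nM, which is a limit and not a number. Within the data shown here, the series so far stands at the limit of > 20000 nM in this assay, at which 3 of the 3 values shown sit, and offers no measured step. Compound 4 `O=C(Nc1cccc(F)c1)c1cc(=O)[nH]c2cc(-c3ccsc3)ccc12` differs from compound 3 by thiophen-3-yl in place of 4-(tert-butyl)phenyl on an aromatic carbon, with thiophen-3-yl in place of 4-(tert-butyl)phenyl on an aromatic carbon. In this assay the expected step of an at least 1.1-fold lower number from compound 3 to compound 4 (0.04 log units; that floor lies within the scatter) is estimated as small and toward stronger inhibition, possibly none beyond the scatter. For compound 4 the estimated value is 18000 nM, with an expected range of 4000 nM to 40000 nM and a real chance that only a limit is reported.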

Compound 4, half-maximal inhibitory concentration: 4300 nM
Compound 4: the middle estimate sits 4.2-fold (0.62 log units) above what was measured; measured number inside the range.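

At this aromatic carbon of the shared core, the substituent can move the series in this assay: thiophen-3-yl in place of 4-(tert-butyl)phenyl gives an at least 4.6-fold lower number from compound 3 to compound 4 (0.66 log units; beyond the scatter). Compound 4 is the only compound shown with a number rather than a limit: the limit of > 20000 nM in this assay, at which 3 of the 4 values shown sit.

The compounds shown do not separate the effect of the thiophene sulfur from that of losing heavy atoms. From the compounds shown here alone, how an unsubstituted phenyl, a pyridine ring or an amine at this carbon would read remains open, as does whether the change carries over to the other anilide groups.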